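A few compounds are considered here, and "the series" means these few. Any claim that something is new, unique, unknown or untested is made for them only; others in the source may bear on it.

Working notes on the series. Compound 1 `CC(NC(=O)NS(=O)(=O)c1ccc(Cl)cc1)c1cc(Br)ccc1OCc1ccccc1` and compound 2 `CC(NC(=O)N(C)S(=O)(=O)c1ccc(Cl)cc1)c1cc(Br)ccc1OCc1ccccc1` share one core and differ only at the amide-type nitrogen. In a functional assay on thoracic aorta (Rattus norvegicus, strain Wistar), with a stated time of 15 min (a lower number here means that less compound is needed, a higher number that more compound is needed for the effect), compound 1 gives 57500 nM, and compound 2 gives 146000 nM. The change hydrogen in place of methyl on an amide-type nitrogen thus gave a 2.5-fold lower number from compound 2 to compound 1 (0.40 log units; beyond the scatter). Compound 3 `CC(NC(=O)N(C)S(=O)(=O)c1ccccc1)c1ccccc1OCc1ccccc1` carries a second core; how that core differs from the core of compound 2 is not broken down here. In this assay, among the compounds with values here, compound 3 gives 21700 nM, the lowest of the three numbers measured so far, with both other compounds beyond the scatter from it. Compound 4 `CC(NC(=O)NS(=O)(=O)c1ccccc1)c1ccccc1OCc1ccccc1` is not yet measured and stands to compound 3 as compound 1 stands to compound 2: hydrogen in place of methyl on an amide-type nitrogen. The place is the same word for word in both pairs, so this is the same change, made twice among the compounds shown. For compound 4 the expected step is a 2.4-fold lower number from compound 3 to compound 4 (0.38 log units; beyond the scatter). Within the data shown here, that rests on the single earlier instance, a 2.5-fold lower number from compound 2 to compound 1 (0.40 log units; beyond the scatter), applied to compound 3 at 21700 nM; with only one precedent the range is kept wide. Compound 4 is therefore estimated at 9000 nM, between 3500 nM and 23000 nM.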

Compound 4, half-maximal effective concentration: > 200000 nM
Compound 4 gave a limit, no number; the forecaster's own chance of this, stated with the estimate: 5%; at least 22-fold (1.34 log units) between middle value and limit.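

In this assay compound 4 gives > 200000 nM, which is a limit of the assay and not a number. On the core of compound 3, hydrogen in place of methyl on an amide-type nitrogen gives an at least 9.2-fold higher number from compound 3 to compound 4 (0.96 log units; beyond the scatter), which runs opposite to the step on the core of compound 2, so the change does not carry from one core to the other in this series: the same change on two cores in this assay, a 2.5-fold lower number (0.40 log units; beyond the scatter) from compound 2 to compound 1 and an at least 9.2-fold higher number (0.96 log units; beyond the scatter) from compound 3 to compound 4, at least 23-fold (1.36 log units) apart, beyond the scatter of two such steps These two pairs do not show which feature of the cores sets the direction of the step, nor how large the step on the core of compound 3 really is.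

At the amide-type nitrogen the compounds shown hold only hydrogen and methyl, so it remains open how an ethyl group or a longer chain would behave there on either core. Also open, on these data alone, is which direction the change takes on a core carrying the chlorine without the bromine, or the bromine without the chlorine.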